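Replacing 4-fluorophenyl in compound 1 with a hydrazine-free name is avoided here

The source may report more compounds than this note shows. Statements on the series, on what has been measured and on what is new or still open speak of the compounds shown alone.

PLACEHOLDER

Sorry, that title and placeholder were a mistake; the correct piece follows.

Replacing 4-fluorophenyl in compound 1

In an ADME assay (Homo sapiens) for cytotoxicity (on this read-out lower numbers stand for higher toxicity in this test and higher numbers for lower toxicity in this test), compound 1 `Nc1nn2c(O)cc(-c3ccc(F)cc3)nc2c1[N+](=O)[O-]` is reported only as a limit, > 100 ug/mL. Compound 3 `Nc1nn2c(O)cc(CNNc3ccc(S(=O)(=O)O)cc3)nc2c1[N+](=O)[O-]` is likewise reported only as a limit, > 50 ug/mL. Compound 2 `NNCc1cc(O)n2nc(N)c([N+](=O)[O-])c2n1` gives a measured 42.6 ug/mL. Compound 4 `Nc1nn2c(O)cc(CNNCCO)nc2c1[N+](=O)[O-]` carries (((2-hydroxyethyl)amino)amino)methyl in place of 4-fluorophenyl on an aromatic carbon. The closest guide is the similar exchange that produced an at least 2.3-fold lower number from compound 1 to compound 2 (0.37 log units; beyond the scatter), a step beyond the scatter. On that basis, a step of similar size towards lower numbers in this assay is expected. The expected change is an at least 1.6-fold lower number from compound 1 to compound 4 (0.22 log units; that floor lies within the scatter). Compound 4 is estimated at 60 ug/mL, with an expected range of 30 ug/mL to 120 ug/mL.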

Compound 4, half-maximal cytotoxic concentration: > 50 ug/mL
Compound 4 gave a limit, no number; the forecaster's own chance of this, stated with the estimate: 35%; the middle value lies beyond the limit too.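

In this assay, 2-hydroxyethyl in place of hydrogen on an amine nitrogen gives an at least 1.1-fold higher number from compound 2 to compound 4 (0.06 log units; that floor lies within the scatter), so this change at the position shows no fall, though it does not establish a rise. The step from compound 1 to compound 4 cannot be read. Compound 4 stands only as a limit, the same one as compound 3: the limit of > 50 ug/mL in this assay, at which 2 of the 4 values shown sit.

As far as these compounds go, the true value of compound 4 in this assay remains open. So does how a plain ethyl or a carboxylic acid on that amine nitrogen would read.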